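This account rests on a few compounds, and the source may have more. Where it says the series, first, only, none or still open, it means among the compounds named here.

Measured compounds:
- compound 1, `N#Cc1c(-c2ccc3c(ccn3[C@H]3CC[C@H](O)CC3)c2)ccn2c(CC(F)(F)F)cnc12` — in a functional assay on CHO cells for agonist activity at metabotropic glutamate receptor 2 (Homo sapiens), read by GTPgammaS binding (on this read-out lower numbers stand for an effect already at smaller amounts and higher numbers for an effect only at larger amounts of compound), compound 1 gives 330 nM
- compound 2, `O[C@H]1CC[C@H](n2ccc3cc(-c4ccn5c(CC(F)(F)F)cnc5c4Cl)ccc32)CC1` — in this assay compound 2 gives 160 nM

Going by the values given here, compound 1 stands at the higher of the two numbers in this assay; the only other compound, compound 2, differs from it by chloro in place of cyano on an aromatic carbon and gives a 2.1-fold lower number from compound 1 to compound 2 (0.31 log units; beyond the scatter). That step is modest and concerns a different place on the shared core.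

Compound 3, `N#Cc1c(-c2ccc3c(ccn3C3CCOCC3)c2)ccn2c(CC(F)(F)F)cnc12`, differs from compound 1 by oxan-4-yl in place of 4-hydroxycyclohexyl on an aromatic nitrogen. Among the compounds with values here, no measured step touches the substituent on that aromatic nitrogen: the single step from compound 1 to compound 2 concerns the aromatic carbon and offers no guidance on the exchange of a 4-hydroxycyclohexyl for an oxan-4-yl. With nothing in this assay to anchor the direction, the step from compound 1 to compound 3 is expected to stay within the usual scatter, a 1.2-fold higher number from compound 1 to compound 3 (0.08 log units; within the scatter), and compound 3 is estimated at 400 nM, with a range from 150 nM to 1100 nM.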

Compound 3, half-maximal effective concentration: 501 nM
The estimate for compound 3 lay 1.3-fold (0.10 log units) below the measured number, and the stated range covers the measured number.
By their numbers in this assay, from the lowest: compound 2; then compounds 1 and 3 (each within the scatter of the next).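

Going by these compounds alone, compound 1 and compound 3 give the first reading on the aromatic nitrogen of the five-membered aromatic ring: in this assay oxan-4-yl in place of 4-hydroxycyclohexyl gives a 1.5-fold higher number from compound 1 to compound 3 (0.18 log units; within the scatter) and so does not separate the two groups. The group that leaves carries 1 hydrogen-bond donor and 2 defined stereocentres, while the group that enters carries 0 hydrogen-bond donors, and in this one pair that exchange leaves the numbers within the scatter of each other, so neither the donor nor the 4-hydroxycyclohexyl ring of carbon only is required to keep the number in this range. No independent measurement is available to explain this result.

Going by these compounds, whether an amine such as piperidin-4-yl, a carboxylic acid on the six-membered ring, or a longer chain on the same aromatic nitrogen would move the number beyond the scatter remains open, as one pair gives no trend for this position. Also open, on these data alone, is whether the exchange would read the same on a core carrying chloro in place of cyano on the aromatic carbon.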